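This account rests on a few compounds, and the source may have more. Where it says the series, first, only, none or still open, it means among the compounds named here.

Measured so far:
- compound 1 `Nc1ncnn2c([C@@H]3O[C@H](CO)[C@@H](O)[C@H]3O)cc(-c3ccccc3F)c12`: 95300 nM
- compound 2 `Cc1ccccc1-c1cc([C@@H]2O[C@H](CO)[C@@H](O)[C@H]2O)n2ncnc(N)c12`: 66000 nM

Within the data shown here, in a functional assay on Z-138 cells (Homo sapiens) for antiproliferative activity, with a stated time of 72 h (a higher number here means a weaker inhibitor, a lower number a stronger inhibitor), compound 2 gives 66000 nM, the lowest of the two numbers, with compound 1 nearest at 95300 nM; the only step, a 1.4-fold lower number from compound 1 to compound 2 (0.16 log units; within the scatter), is within the scatter, so the two stand level.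

Compound 3 `Nc1ncnn2c([C@@H]3O[C@H](CO)[C@@H](O)[C@H]3O)cc(-c3ccsc3)c12` differs from compound 2 by thiophen-3-yl in place of 2-methylphenyl on an aromatic carbon. Among the measured compounds shown here, no measured step exchanges a six-membered ring of carbon only for a five-membered ring with one hetero atom at this position; the single step, a 1.4-fold lower number from compound 1 to compound 2 (0.16 log units; within the scatter), concerns a substituent on the aryl ring and is flat. There is therefore nothing to carry over beyond the observation that both measured compounds sit at weak, high numbers in this assay.

Compound 3 is expected to stay near compound 2, a step of a 1.2-fold higher number from compound 2 to compound 3 (0.08 log units; within the scatter), since a 1.4-fold lower number from compound 1 to compound 2 (0.16 log units; within the scatter) shows the aryl change hardly moving the number. The estimate for compound 3 in this assay is 80000 nM, within 30000 nM to 200000 nM.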

Compound 3, half-maximal inhibitory concentration: 43500 nM
Compound 3: middle estimate off by 1.8-fold (0.26 log units), on the high side; low and high end bracket the measured number.
By their numbers in this assay, from the lowest: compounds 3, 2 and 1 (each within the scatter of the next, the first and the last beyond it).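

In this assay, the position on an aromatic carbon of a five-membered aromatic ring with 1 nitrogen takes a five-membered aromatic ring with 1 hetero atom in place of a six-membered aromatic ring of carbon only, with no loss. Thiophen-3-yl in place of 2-methylphenyl gives a 1.5-fold lower number from compound 2 to compound 3 (0.18 log units; within the scatter) and stays level, while thiophen-3-yl in place of 2-fluorophenyl gives a 2.2-fold lower number from compound 1 to compound 3 (0.34 log units; beyond the scatter) and is the first step in the series beyond the scatter, though a modest one. No measurement at hand accounts for this small shift.

On these data alone, all three compounds still sit at high numbers, so how far any change at this position can move the number remains open. Whether an amine, a carboxylic acid or a longer alkyl chain here would shift it beyond this narrow range also stays unresolved.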